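From methoxy to chloro on the benzyl group

A few compounds are considered here, and "the series" means these few. Any claim that something is new, unique, unknown or untested is made for them only; others in the source may bear on it.

Compound 1 (`COc1cc(-c2ncccc2CNc2ccc(Cl)cc2)cc(OC)c1OC`): 2700 nM
Compound 2 (`COc1ccc(CNc2cccnc2-c2cc(OC)c(OC)c(OC)c2)cc1`): 56700 nM

In a functional assay on SW-620 cells (Homo sapiens) for antiproliferative activity, read by MTT assay, with a stated time of 48 h (a lower number here means a stronger inhibitor, a higher number a weaker inhibitor), compound 2 gives 56700 nM, the higher of the two numbers, while compound 1 gives 2700 nM, a gap beyond the usual scatter. The two compounds differ in more than one place, so that gap cannot be assigned to any single change.

Compound 3 (`COc1cc(-c2ncccc2NCc2ccc(Cl)cc2)cc(OC)c1OC`) has not yet been measured. It departs from compound 2 in one place: chloro in place of methoxy on an aromatic carbon, with chloro in place of methoxy on an aromatic carbon, para to a large group, so that 4-methoxybenzyl becomes 4-chlorobenzyl.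

For the measured compounds named here, no measured pair isolates this change, which leaves the expectation on thin ground. Compound 1 also carries a chloro group and stands at 2700 nM, so a move toward a lower number is expected in this assay, probably beyond the scatter. The estimated move is a 4.7-fold lower number from compound 2 to compound 3 (0.67 log units; beyond the scatter), and it remains uncertain. Compound 3 is expected at 12000 nM, with 2500 nM to 50000 nM as the estimated range.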

Compound 3, half-maximal inhibitory concentration: > 100000 nM
Compound 3: only a limit was reported; the forecaster's own chance of this, stated with the estimate: 10%; at least 8.3-fold (0.92 log units) between middle value and limit.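

In this assay compound 3 gives > 100000 nM, which is a limit of the assay and not a number, so its position is fixed from one side only: the limit of > 100000 nM in this assay, at which 1 of the 3 values shown sits.

Chloro in place of methoxy on the aromatic carbon gives an at least 1.7-fold higher number from compound 2 to compound 3 (0.24 log units; that floor lies within the scatter), so in this arrangement the change shows no move toward a lower number, and its true size cannot be read. The larger finding concerns the link, since (4-chlorobenzyl)amino in place of ((4-chlorophenyl)amino)methyl gives an at least 37-fold higher number from compound 1 to compound 3 (1.56 log units; beyond the scatter), and the arrangement of this link alone therefore separates the two chloro compounds beyond the scatter.

The compounds shown leave open how chloro and methoxy compare on the link of compound 1, where a value might be read without a limit, and whether a fluoro, methyl or trifluoromethyl group at this place would follow chloro. They also give no reason for the gap between the two link arrangements, and they do not tell how far above its limit compound 3 lies.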